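Free fraction after changing the side group of compound 1

The source may hold more compounds than are shown below. What is called first, only, known or untested is meant among the compounds shown, and "the series" means these compounds.

In an ADME assay on a cell-free system (plasma, Homo sapiens) (on this read-out higher numbers stand for a larger free fraction and lower numbers for a smaller free fraction), compound 1 (`CCc1c(CN2CC(C(=O)O)C2)cccc1-c1nsc(-c2ccc(OC(C)C)c(C(F)(F)F)c2)n1`) gives 0.0026 and sits level with compound 3 (`CCc1c(CCCC(=O)O)cccc1-c1nsc(-c2ccc(OC(C)C)c(C#N)c2)n1`) at 0.0021 within the usual scatter. Compound 2 (`CCc1c(CN2CC(C(=O)O)C2)cccc1-c1nsc(-c2ccc(OC(C)C)c(Cl)c2)n1`) stands clearly higher at 0.0096 on this scale.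

Compound 4 (`CCc1c(CN(C)C(C)(C)C(=O)O)cccc1-c1nsc(-c2ccc(OC(C)C)c(C(F)(F)F)c2)n1`) has not been measured. It carries (1-carboxy-1-methylethyl)(methyl)amino in place of the 3-carboxyazetidin-1-yl of compound 1 on a saturated chain carbon bound to an aromatic carbon ((1-carboxy-1-methylethyl)(methyl)amino in place of 3-carboxyazetidin-1-yl on a saturated chain carbon bound to an aromatic carbon), so the four-membered ring is gone.

For the measured compounds named here, the only measured step is a 3.7-fold higher number from compound 1 to compound 2 (0.57 log units; beyond the scatter) and it is modest, but it swaps trifluoromethyl for chloro, and compound 4 keeps the trifluoromethyl. Compound 3 differs from compound 1 in its chain and also has a nitrile, so compound 3 at 0.0021 cannot isolate this change. With no measured change at this place, no shift beyond the scatter is expected in this assay and the estimated step is a 1.1-fold lower number from compound 1 to compound 4 (0.03 log units; within the scatter) for this swap. Compound 4 is estimated at 0.0024 (expected range 0.0011 to 0.0055).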

Compound 4, unbound fraction: 0.00004
The estimate for compound 4 lay 60-fold (1.78 log units) above the measured number, and the stated range ends above it.
By their numbers in this assay, from the lowest: compound 4; then compounds 3 and 1 (each within the scatter of the next); then compound 2.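

At this place, on a saturated chain carbon bound to an aromatic carbon, the side group turns out to matter strongly in this assay: (1-carboxy-1-methylethyl)(methyl)amino in place of 3-carboxyazetidin-1-yl gives a 65-fold lower number from compound 1 to compound 4 (1.81 log units; beyond the scatter). The earlier step, a 3.7-fold higher number from compound 1 to compound 2 (0.57 log units; beyond the scatter), showed only a modest change on an aromatic carbon, whereas this one is large even though both groups count the same nitrogen, oxygens, hydrogen-bond donor and acceptors, and differ in the lost four-membered ring and one added carbon. Nothing measured here explains why the free fraction moves so far.

The compounds shown cannot separate the loss of the ring from the added carbon. An open chain such as (carboxymethyl)(methyl)amino, or a larger ring such as 3-carboxypyrrolidin-1-yl, would help tell these two apart.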